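A few compounds are considered here, and "the series" means these few. Any claim that something is new, unique, unknown or untested is made for them only; others in the source may bear on it.

Measured so far:

Compound 1: `O=C(CN(c1nc(Cl)nc2[nH]cnc12)C1CC1)N[C@@H](CCC(=O)OCc1ccccc1)C(=O)OCc1ccccc1` — in a functional assay on the whole organism (Tail, strain ICR) with Mus musculus as the target, in the tail flick test, with a stated time of 150 min, at a dose of 25 umol/kg by the oral route (on this read-out higher numbers stand for a stronger effect at the one dose given and lower numbers for a weaker effect), compound 1 gives 44.5%.
Compound 2: `O=C(O)CC[C@H](NC(=O)CN(c1nc(Cl)nc2[nH]cnc12)C1CC1)C(=O)O` — in this assay compound 2 gives 29.5%.

For the measured compounds named here, only two compounds have been measured, and compound 2 gives the lower of the two numbers. The nearer comparison is compound 1, whose read-out lies above that of compound 2 by a margin that goes beyond the usual scatter of repeated measurements, so the two can be told apart. Going by the values given here, no single-point step between measured compounds is available, so there is no measured change of the same kind to lean on.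

The next compound is compound 3: `CC(C)[C@H](NC(=O)CN(c1nc(Cl)nc2[nH]cnc12)C1CC1)C(=O)O`. Compared with compound 2 it carries one change: isopropyl in place of 2-carboxyethyl on a saturated chain carbon bound to an amide-type nitrogen and a carbonyl carbon. The 2-carboxyethyl group leaves and an isopropyl group enters at the same saturated chain carbon, the one bound to an amide-type nitrogen and a carbonyl carbon.

With only the value of compound 2, 29.5%, as the starting point, the step from compound 2 to compound 3 is expected to be small, a number 3.5 percentage points higher from compound 2 to compound 3 (within the scatter), not clearly beyond the scatter in either direction. Compound 3 is therefore estimated to give about 33% in this assay, with a likely range from 15% to 52%.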

Compound 3, a percentage reported as activity, at one dose (the size of the read-out at that dose, not a potency): 7.86%
The estimate for compound 3 lay 25.1 percentage points above the measured number; measured number outside the range, below it.
By their numbers in this assay, from the lowest: compound 3; then compound 2; then compound 1.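

At the saturated chain carbon bound to an amide-type nitrogen and a carbonyl carbon, the group carried there clearly matters: in this assay, isopropyl in place of 2-carboxyethyl gives a number 21.6 percentage points lower from compound 2 to compound 3 (beyond the scatter), a step beyond the usual scatter. For the compounds shown here, this is the first single-place change, and it shows that the read-out responds to this position even with the rest of the molecule held constant. The change swaps a group of five heavy atoms, with a hydrogen-bond donor and acceptor, for one of three heavy atoms with neither, but no measurement here links the step to any property of either group.

The compounds shown leave open whether the step follows the loss of the carboxylic acid from the side chain or the swap of a straight chain for a branched one, as both differences arrive together in this single change. As far as these compounds go, it also remains open where a 2-carbamoylethyl group, which has an amide in place of the carboxylic acid, or a plain n-propyl chain at this carbon would fall relative to compound 2 and compound 3.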